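Opening a Small Ring into a Straight Chain

The source may report more compounds than this note shows. Statements on the series, on what has been measured and on what is new or still open speak of the compounds shown alone.

Three compounds share one core and differ only in the group on the oxygen. In an assay on cells with melanin-concentrating hormone receptor 1 (Homo sapiens) as the target, read by radioligand binding (on this read-out lower numbers stand for stronger inhibition and higher numbers for weaker inhibition), compound 1 `CC1CCC(Oc2cccc3ccc(N)nc23)C1` gives 823 nM, and compound 3 `CC1CC1COc1cccc2ccc(N)nc12` gives 1640 nM, the higher of the two plain numbers, a gap that a 2.0-fold higher number from compound 1 to compound 3 (0.30 log units; within the scatter) places within the scatter. Compound 2 `CC#CCCOc1cccc2ccc(N)nc12` reaches only a limit of the assay, > 2000 nM. Compound 4 `CCCCCOc1cccc2ccc(N)nc12` is compound 3 with a change of butyl in place of 2-methylcyclopropyl on a saturated chain carbon bound to an oxygen on an aromatic ring. Going by the values given here, the steps that bear on this are an at least 2.4-fold higher number from compound 1 to compound 2 (0.38 log units; beyond the scatter), a ring giving way to a chain, and an at least 1.2-fold lower number from compound 2 to compound 3 (0.08 log units; that floor lies within the scatter), a chain giving way to a ring. Since both point the same way, compound 4 is expected to show a modest rise, a 1.5-fold higher number from compound 3 to compound 4 (0.18 log units; within the scatter). Compound 4 is therefore estimated at 2500 nM, with a range from 1200 nM to 6000 nM.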

Compound 4, half-maximal inhibitory concentration: 580 nM
Compound 4: middle estimate off by 4.3-fold (0.63 log units), on the high side, outside the stated range (below it).
By their numbers in this assay, from the lowest: compounds 4, 1 and 3 (each within the scatter of the next, the first and the last beyond it). At a limit, above all of these: compound 2.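

Putting butyl in place of 2-methylcyclopropyl lowers the number (a 2.8-fold lower number from compound 3 to compound 4 (0.45 log units; beyond the scatter)), so a ring at this place is not needed for binding. The pentyl chain of compound 4 also shows no difference beyond the scatter from the 3-methylcyclopentyl group (a 1.4-fold lower number from compound 1 to compound 4 (0.15 log units; within the scatter)). Propyl in place of prop-1-yn-1-yl lowers the number too (an at least 3.4-fold lower number from compound 2 to compound 4 (0.53 log units; beyond the scatter)), though this step is only a floor, since the value of compound 2 is a limit of the assay. From the compounds shown here alone, whether a longer chain such as hexyl, or an amine at the chain end, would lower the number further remains open.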